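The source may report more compounds than this note shows. Statements on the series, on what has been measured and on what is new or still open speak of the compounds shown alone.

Compound 1, with the structure `COc1ccc([C@H]2CC(C)(O)[C@@H]3CC[C@@H](C)C[C@H]3O2)cc1`, was examined in an ADME assay on MDCK cells (Canis lupus familiaris) for cytotoxicity, read by MTT assay, with a stated time of 48 h (on this read-out lower numbers stand for higher toxicity in this test and higher numbers for lower toxicity in this test), where compound 1 gives 689000 nM. Compound 2, with the structure `COc1ccc([C@H]2CC(C)(O)[C@@H]3CC[C@@H](C)C[C@H]3O2)cc1O`, differs from compound 1 by hydroxy in place of hydrogen on an aromatic carbon. In this assay compound 2 gives 738000 nM, and the step of a 1.1-fold higher number from compound 1 to compound 2 (0.03 log units; within the scatter) is within the usual scatter of this measurement.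

Compound 3, with the structure `C[C@@H]1CC[C@@H]2[C@@H](C1)O[C@@H](c1ccccc1)CC2(C)F`, carries a different core; the difference between the two cores is not broken down here. In this assay compound 3 gives 65000 nM, the lowest of the three numbers recorded, and its gaps to compound 1 and to compound 2 lie beyond the scatter.

Compound 4, with the structure `C[C@@H]1CC[C@@H]2[C@@H](C1)O[C@@H](c1ccccc1O)CC2(C)F`, has not been measured. It differs from compound 3 by hydroxy in place of hydrogen on an aromatic carbon. This is the same kind of change as that from compound 1 to compound 2, though the surroundings differ: in compound 2 the new group is ortho to a methoxy group and meta to a large group, whereas in compound 4 it is ortho to a large group.

Because the earlier step of a 1.1-fold higher number from compound 1 to compound 2 (0.03 log units; within the scatter) on the first core did not move the number beyond the scatter, the step of a 1.1-fold higher number from compound 3 to compound 4 (0.03 log units; within the scatter) is expected to be similarly small. Compound 4 is therefore estimated to give 70000 nM in this assay, with a likely range from 30000 nM to 160000 nM.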

Compound 4, half-maximal cytotoxic concentration: 44000 nM
For compound 4 the middle estimate is 1.6-fold (0.20 log units) above the measured one, within the range that was stated.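

In this assay, hydroxy in place of hydrogen on an aromatic carbon gives a 1.5-fold lower number from compound 3 to compound 4 (0.17 log units; within the scatter), so on the core of compound 3, as on the core of compound 1, this change leaves the read-out within the usual scatter. Set side by side, the two steps do not differ by more than repeated measurements of this kind would allow: the same change on two cores in this assay, a 1.1-fold higher number (0.03 log units; within the scatter) from compound 1 to compound 2 and a 1.5-fold lower number (0.17 log units; within the scatter) from compound 3 to compound 4, 1.6-fold (0.20 log units) apart, within the scatter of two such steps. Among these compounds, this shows that in this test the change carried from one core to the other without a readable shift on either, including where the new hydroxy stands ortho to a large group in compound 4, but it rests on only two pairs of compounds and does not show that the change would be equally silent on any further core or in any other test.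

The compounds shown leave open whether a different group in the same place, such as an amine or a carboxylic acid, would also stay within the scatter. They also leave open whether hydroxy would do so at other places on the aromatic ring of the core of compound 3.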